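A few compounds are considered here, and "the series" means these few. Any claim that something is new, unique, unknown or untested is made for them only; others in the source may bear on it.

Measured compounds:
compound 1 `O=S(=O)(Nc1cccc2c1CCCC2c1c[nH]cn1)C1CC1` — in an assay on isolated protein (Cricetulus griseus) for binding affinity to Alpha-1B adrenergic receptor (Mesocricetus auratus), read by radioligand binding (on this read-out higher numbers stand for weaker inhibition and lower numbers for stronger inhibition), compound 1 gives < 10000 nM
compound 2 `CC(c1cccc(NS(C)(=O)=O)c1)c1c[nH]cn1` — in this assay compound 2 gives < 10000 nM

The value shown for compound 1 is a limit of the assay rather than a number. The value for compound 2 is likewise a limit, so both sit at the limit of < 10000 nM in this assay, at which 2 of the 2 values shown sit, and compound 1 cannot be placed above or below any other entry. Compound 3 `COC(=O)Nc1cccc2c1CCCC2c1c[nH]cn1` differs from compound 1 by methoxycarbonyl in place of cyclopropylsulfonyl on a nitrogen on an aromatic ring. For the measured compounds named here, with no step between measured compounds known, no change beyond the usual scatter is expected in this assay from compound 1 to compound 3. Compound 3 is therefore estimated at 800 nM, within 80 nM to 8000 nM, a step that the limit leaves unreadable from compound 1 to compound 3.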

Compound 3, inhibition constant: 10000 nM
Beside the measured number, compound 3's estimate is 13-fold (1.10 log units) below it; measured number above the stated range.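

With methoxycarbonyl in place of cyclopropylsulfonyl on a nitrogen on an aromatic ring, this assay shows a number no lower from compound 1 to compound 3 (the limit leaves the size open). Compound 3 gives a plain number at this position, 10000 nM. The value of compound 1 is a limit, so the size of this step cannot be read, and the set still rests largely on limits: the limit of < 10000 nM in this assay, at which 2 of the 3 values shown sit.

The compounds shown leave open how far compound 1 really lies from compound 3. They also leave open what an acetyl group or an ethoxycarbonyl group on that nitrogen would give.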